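Compound 4 and a Ceiling in Tolerated Concentration

A few compounds are considered here, and "the series" means these few. Any claim that something is new, unique, unknown or untested is made for them only; others in the source may bear on it.

In an ADME assay on HCT-116 cells (Homo sapiens) for cytotoxicity, read by MTT assay (a higher number here means that more compound is tolerated, a lower number that less compound is tolerated), compound 1 (`Cc1nc(-c2cccnc2)sc1-c1nnc(-c2ccc(Br)cc2)o1`) gives > 100 ug/mL as its read-out, and this is a limit, not a number. Compound 2 (`Cc1nc(-c2cccnc2)sc1-c1nnc(-c2ccccc2Cl)o1`) gives > 100 ug/mL, which is also a limit. Compound 3 (`Cc1nc(-c2cccnc2)sc1-c1nnc(-c2ccc([N+](=O)[O-])cc2)o1`) gives > 100 ug/mL, again a limit. All three thus sit at one ceiling, which is the limit of > 100 ug/mL in this assay, at which 3 of the 3 values shown sit, for this series.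

Compound 4 (`COc1ccccc1-c1nnc(-c2sc(-c3cccnc3)nc2C)o1`) carries 2-methoxyphenyl in place of 4-bromophenyl on an aromatic carbon of a five-membered aromatic ring with 2 nitrogen and 1 oxygen (2-methoxyphenyl in place of 4-bromophenyl on an aromatic carbon).

Two measured changes bear on this one, a step that the two limits leave unreadable from compound 1 to compound 2 and a step that the two limits leave unreadable from compound 1 to compound 3, and neither yields a size. With no readable step to draw on, no change beyond the usual scatter is expected in this assay. The expected change is a step that the limit leaves unreadable from compound 1 to compound 4. Compound 4 is estimated at 120 ug/mL, with an expected range from 60 ug/mL to 240 ug/mL, and the assay may well report only a limit.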

Compound 4, half-maximal cytotoxic concentration: > 100 ug/mL
Compound 4 ended at the assay's limit; the forecaster's own chance of this, stated with the estimate: 80%; the middle value is on the limit's open side.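

Neither the step from compound 1 to compound 4 nor the step from compound 2 to compound 4 can be read, for compound 4 also stands at a limit: the limit of > 100 ug/mL in this assay, at which 4 of the 4 values shown sit.

The compounds shown leave open how much of each is actually tolerated in this assay, and whether any change on the shared core would bring a value under that ceiling.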